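Chain extension beyond compound 2: working notes

The source may report more compounds than this note shows. Statements on the series, on what has been measured and on what is new or still open speak of the compounds shown alone.

In a functional assay on brain (Rattus norvegicus, strain Wistar) for inhibition (on this read-out lower numbers stand for stronger inhibition and higher numbers for weaker inhibition), compound 1 (`CCCCCCOc1ccc(-c2c(C)[nH]c(=O)n2C2CCCCC2)cc1`) gives 8500 nM, and compound 2 (`CCCCCCCCCCCCOc1ccc(-c2c(C)[nH]c(=O)n2C2CCCCC2)cc1`) gives 52400 nM, the higher of the two numbers. Compound 3 (`CCCCCCCCCCCCCCCCCCOc1ccc(-c2c(C)[nH]c(=O)n2C2CCCCC2)cc1`) differs from compound 2 by hexyl in place of hydrogen on a saturated chain carbon, ten or more bonds along the chain from an oxygen on an aromatic ring. Within the data shown here, the one measured step bearing on this, a 6.2-fold higher number from compound 1 to compound 2 (0.79 log units; beyond the scatter), is the same exchange nearer the oxygen. A further rise in this assay of similar or smaller size is therefore expected, though one step sets no trend. The expected change is a 3.4-fold higher number from compound 2 to compound 3 (0.54 log units; beyond the scatter). Compound 3 is estimated at 180000 nM, with a range of 60000 nM to 500000 nM.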

Compound 3, half-maximal inhibitory concentration: > 100000 nM
Compound 3: a limit, no number; the forecaster's own chance of this, stated with the estimate: 35%; the middle value is on the limit's open side.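

In this assay compound 3 carries a limit of the assay, not a number: the limit of > 100000 nM in this assay, at which 1 of the 3 values shown sits.

Read against the previous chain, this gives an at least 1.9-fold higher number from compound 2 to compound 3 (0.28 log units; that floor lies within the scatter), so the added hexyl at this position is not shown to weaken inhibition further. Over the whole series the dodecyl exchange gives an at least 11-fold higher number from compound 1 to compound 3 (1.07 log units; beyond the scatter), which extends the direction of a 6.2-fold higher number from compound 1 to compound 2 (0.79 log units; beyond the scatter) across all three compounds, with no return of inhibition at the longest chain.

From the compounds shown here alone, how far compound 3 lies past its limit stays open. So does how a butyl chain, or an amine in place of the chain, would read in this assay.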